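Phenyl added to the propyl chain of compound 2

A few compounds are considered here, and "the series" means these few. Any claim that something is new, unique, unknown or untested is made for them only; others in the source may bear on it.

Within the data shown here, compound 2 `CCCNC(=O)/N=C(\N)NCCCc1sc(N)nc1C` gives 105 nM in an assay on membranes from Sf9 cells for displacement of a labelled ligand from histamine H2 receptor (Homo sapiens), read by scintillation counting, with a stated time of 60 min (a lower number here means a stronger inhibitor, a higher number a weaker inhibitor), and stands highest of the three numbers measured so far. Compound 1 `Cc1nc(N)sc1CCCN/C(N)=N/C(=O)N[C@H](C)c1ccccc1` gives 17.8 nM in this assay, and compound 3 `Cc1nc(N)sc1CCCN/C(N)=N/C(=O)NCc1ccco1` gives 10.5 nM in this assay. The step from the first to the second was a 5.9-fold higher number from compound 1 to compound 2 (0.77 log units; beyond the scatter), the step to the third was a 1.7-fold lower number from compound 1 to compound 3 (0.23 log units; within the scatter), and between the two remaining ones it was a 10-fold lower number from compound 2 to compound 3 (1.00 log units; beyond the scatter).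

Compound 4 `CCC(NC(=O)/N=C(\N)NCCCc1sc(N)nc1C)c1ccccc1` differs from compound 2 by phenyl in place of hydrogen on a saturated chain carbon bound to an amide-type nitrogen and a saturated chain carbon. Among the measured compounds shown here, two measured steps bear on this change. The first, a 5.9-fold higher number from compound 1 to compound 2 (0.77 log units; beyond the scatter), shows that going from 1-phenylethyl to plain propyl raised the number beyond the scatter. The second, a 10-fold lower number from compound 2 to compound 3 (1.00 log units; beyond the scatter), shows that placing a ring on the saturated carbon bound to the amide-type nitrogen lowered it. Compound 4 combines the phenyl of compound 1 with the propyl chain of compound 2, so a lower number beyond the scatter is expected. For compound 4 the expected step is therefore a 5.3-fold lower number from compound 2 to compound 4 (0.72 log units; beyond the scatter). Compound 4 is estimated at 20 nM in this assay, with a range from 8 nM to 50 nM.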

Compound 4, inhibition constant: 63.1 nM
Compound 4: the middle estimate sits 3.2-fold (0.50 log units) below what was measured; the whole stated range lies below it.
By their numbers in this assay, from the lowest: compounds 3 and 1 (each within the scatter of the next); then compounds 4 and 2 (each within the scatter of the next).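

In this assay, phenyl in place of hydrogen on this saturated chain carbon gives a 1.7-fold lower number from compound 2 to compound 4 (0.22 log units; within the scatter), a step that stays within the scatter, so on the propyl chain this change shows no clear effect on the number. Adding phenyl at this position is therefore not enough on its own to produce a step beyond the scatter of the size of a 5.9-fold higher number from compound 1 to compound 2 (0.77 log units; beyond the scatter), even though compound 1 also carries phenyl on the carbon bound to the amide-type nitrogen. Nothing shown explains this result.

Going by these compounds, compound 4 is drawn without a defined configuration at this carbon, so any difference between its two mirror-image forms remains open. Also open, on these data alone, is whether a hydroxyl, an amine or a longer chain such as butyl on this carbon would move the number beyond the scatter.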